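From ethoxycarbonyl to methoxycarbonyl: compound 3 to compound 4

This account rests on a few compounds, and the source may have more. Where it says the series, first, only, none or still open, it means among the compounds named here.

Measured so far in a toxicity assay on NIH3T3 cells (Mus musculus) for cytotoxicity, read by resazurin assay; on this read-out higher numbers stand for an effect only at larger amounts of compound and lower numbers for an effect already at smaller amounts:
- Compound 1 `O=C(c1ccc(NCc2cncn2Cc2ccc(-c3ccccc3)cc2)cc1-c1ccccc1)N1CCCCC1`: > 1000 nM (a limit)
- Compound 2 `COC(=O)c1ccc(NCc2cncn2Cc2ccccc2C)cc1-c1ccccc1`: 10000 nM
- Compound 3 `CCOC(=O)c1ccc(NCc2cncn2Cc2ccc(-c3ccccc3)cc2)cc1-c1ccccc1`: > 10000 nM (a limit)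

In this assay compound 3 has no exact number, only the limit > 10000 nM. Compound 1 also has only a limit.

Compound 4 `COC(=O)c1ccc(NCc2cncn2Cc2ccc(-c3ccccc3)cc2)cc1-c1ccccc1` differs from compound 3 in one place, ethoxycarbonyl to methoxycarbonyl: hydrogen in place of methyl on a saturated chain carbon bound to an oxygen next to a carbonyl group. In words, hydrogen stands in place of methyl on a saturated chain carbon bound to an oxygen next to a carbonyl group.

Going by the values given here, the one measured step is a step that the two limits leave unreadable from compound 1 to compound 3, so it gives no size to build on. Compound 2 also carries methoxycarbonyl, though it differs elsewhere, and compound 2 gives 10000 nM.

With so little to go on, no change beyond the usual scatter is expected, and the estimated step is a number no higher from compound 3 to compound 4 (the limit leaves the size open). For compound 4 the expected value is 10000 nM, with an estimated range of 3000 nM to 30000 nM.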

Compound 4, half-maximal effective concentration: > 1000 nM
Compound 4 ended at the assay's limit; the forecaster's own chance of this, stated with the estimate: 60%; the middle value is on the limit's open side.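

None of the steps from compound 1, compound 2 or compound 3 to compound 4 can be read, since each rests on at least one limit rather than a number. The compounds shown leave open whether going from ethoxycarbonyl to methoxycarbonyl changes the result in this assay at all.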